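Replacing a dimethylamino-bearing aryl with a fluoro-methyl aryl

The source may report more compounds than this note shows. Statements on the series, on what has been measured and on what is new or still open speak of the compounds shown alone.

Compound 3, `CC[C@@H](Nc1c(C#N)c(-c2ccc(-c3ccccc3N(C)C)cc2)nc2cnccc12)C(N)=O`, gives 3.2 in a physicochemical assay for lipophilicity, read by HPLC, at pH 7.5 (on this read-out higher numbers stand for higher lipophilicity and lower numbers for lower lipophilicity), the highest of the three numbers measured. Compound 1, `CC[C@@H](Nc1c(C#N)c(-c2ccc(-c3ccccc3C(F)(F)F)cc2)nc2cnccc12)C(N)=O`, gives 3.1, and compound 2, `CC[C@@H](Nc1c(C#N)c(-c2ccc(-c3cccc(CO)c3)cc2)nc2cnccc12)C(N)=O`, gives 2. The two steps into compound 3 differ greatly in size: a number 1.20 log units higher from compound 2 to compound 3 (beyond the scatter), whereas a number 0.10 log units higher from compound 1 to compound 3 (within the scatter). Compound 4, `CC[C@@H](Nc1c(C#N)c(-c2ccc(-c3cccc(C)c3F)cc2)nc2cnccc12)C(N)=O`, differs from compound 3 as follows: 2-fluoro-3-methylphenyl in place of 2-(dimethylamino)phenyl on an aromatic carbon. Since the step from compound 1 to compound 3 was within the scatter, and compound 4 carries neither a hydrogen-bond acceptor nor a hydroxymethyl, the step from compound 3 to compound 4 is expected to stay within the scatter, estimated as a number 0.10 log units higher from compound 3 to compound 4 (within the scatter). Compound 4 is therefore estimated at 3.3, with a range from 2.9 to 3.7.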

Compound 4, distribution coefficient: 3
The estimate for compound 4 lay 0.30 log units above the measured number, and the stated range covers the measured number.
By their numbers in this assay, from the lowest: compound 2; then compounds 4, 1 and 3 (each within the scatter of the next).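

In this assay, the 2-fluoro-3-methylphenyl group gives a number 0.20 log units lower from compound 3 to compound 4 (within the scatter) and a number 0.10 log units lower from compound 1 to compound 4 (within the scatter), but a number 1.00 log units higher from compound 2 to compound 4 (beyond the scatter). At this aromatic carbon, para to a large group, a third aryl group thus joins those of compound 1 and compound 3 within the scatter, though it has no hydrogen-bond acceptor where the 2-(dimethylamino)phenyl has one, and compound 2 alone stands apart. Nothing available explains these steps.

On these data alone, whether the hydroxymethyl alone sets compound 2 apart remains open. So does how a carboxylic acid or a primary amine on this aryl ring would read in this assay.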